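Acylating the amine of compound 2 in a kinase binding assay

This account rests on a few compounds, and the source may have more. Where it says the series, first, only, none or still open, it means among the compounds named here.

Measured compounds:
compound 1, `CN(C)CCNc1nc([C@@H]2CNC[C@H]2c2ccc(F)cc2)nc2ccc(-c3cn[nH]c3)cc12`, 371 nM
compound 2, `NC(c1ccc(Cl)cc1)c1nc2ccc(-c3cn[nH]c3)cc2c(=O)[nH]1`, 10 nM

Of the compounds shown here, two have been tested in an in vitro binding assay on Sf9 cells for inhibition of Rho-associated protein kinase 2 (Homo sapiens), read by TR-FRET, with a stated time of 25 min; a higher number here means a weaker inhibitor, a lower number a stronger inhibitor. Compound 1 has the structure `CN(C)CCNc1nc([C@@H]2CNC[C@H]2c2ccc(F)cc2)nc2ccc(-c3cn[nH]c3)cc12` and in this assay gives 371 nM. Compound 2, with the structure `NC(c1ccc(Cl)cc1)c1nc2ccc(-c3cn[nH]c3)cc2c(=O)[nH]1`, gives 10 nM in this assay, the lower of the two numbers, and the gap between them lies well beyond the usual scatter. Compound 2 is therefore the stronger inhibitor of the pair shown.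

Compound 3, with the structure `NCCC(=O)NC(c1ccc(Cl)cc1)c1nc2ccc(-c3cn[nH]c3)cc2c(=O)[nH]1`, has not yet been measured. It differs from compound 2 at a single place: (2-aminoethyl)carbonyl in place of hydrogen on an amine nitrogen. Going by the values given here, no pair of measured compounds here differs in only one place, so there is no step already seen that speaks directly to this change.

Given that absence, only a cautious expectation is possible. The step from compound 2 to compound 3 is expected to be small, a 2.0-fold higher number from compound 2 to compound 3 (0.30 log units; within the scatter), within or only slightly beyond the scatter, leaning toward a somewhat weaker inhibitor. For compound 3 in this assay, the expected value is 20 nM, with a range from 5 nM to 80 nM.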

Compound 3, half-maximal inhibitory concentration: 6 nM
The estimate for compound 3 lay 3.3-fold (0.52 log units) above the measured number, within the range that was stated.
By their numbers in this assay, from the lowest: compounds 3 and 2 (each within the scatter of the next); then compound 1.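

Compound 2 carries a bare amine, so until now nothing showed whether that nitrogen's hydrogen could be replaced at all. In this assay the step is a 1.7-fold lower number from compound 2 to compound 3 (0.22 log units; within the scatter) and this places the two compounds within the scatter of each other, so the assay cannot tell them apart. This position therefore accepts (2-aminoethyl)carbonyl, a group of 5 heavy atoms that turns the amine into an amide, with no difference beyond the scatter, and a free amine on that carbon is not needed for a number of this size. No accompanying measurement offers an explanation for this result.

The compounds shown leave open whether the amino group of the added chain matters, since an acetyl group, which has the carbonyl but no amine, would separate the effect of the carbonyl from that of the amine. They also leave open how far the position stretches, for instance whether a longer chain or a carboxylic acid in place of that amine would give a number in the same range.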